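The source may report more compounds than this note shows. Statements on the series, on what has been measured and on what is new or still open speak of the compounds shown alone.

Measured so far in an ADME assay on BJ cells (Homo sapiens) for cytotoxicity, read by MTT assay, with a stated time of 72 h; on this read-out lower numbers stand for stronger inhibition and higher numbers for weaker inhibition:
- Compound 1 `COc1ccc(OC)c(CNc2ncnc3c2ncn3C2CCCCO2)c1` gives > 100000 nM (a limit)
- Compound 2 `COc1ccc(CNc2ncnc3c2ncn3C2CCCCO2)cc1OC` gives > 100000 nM (a limit)
- Compound 3 `COc1cc(OC)c(OC)cc1CNc1ncnc2c1ncn2C1CCCCO1` gives > 100000 nM (a limit)

Compound 3 has no numerical value, only a limit, and it stands with the other two compounds at the same point: the limit of > 100000 nM in this assay, at which 3 of the 3 values shown sit, is all the series shows so far. The next compound is compound 4 `COc1cc(OC)c(OC)cc1CNc1ncnc2c1ncn2C1CCCO1` with the change oxolan-2-yl in place of oxan-2-yl on an aromatic nitrogen in which oxolan-2-yl replaces oxan-2-yl on an aromatic nitrogen.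

Two measured steps end at compound 3, namely a step that the two limits leave unreadable from compound 1 to compound 3 and a step that the two limits leave unreadable from compound 2 to compound 3 as the size of each cannot be read. Both are a different change, methoxy in place of hydrogen on an aromatic carbon, so they bear on the new change only indirectly. Among the measured compounds shown here, no measured step alters the group on the aromatic nitrogen.

In this assay no step beyond the usual scatter is expected, and a further limit is the likeliest report. This expectation rests on compound 3 with its limit of > 100000 nM as the nearest reference. The expected step is a number no higher from compound 3 to compound 4 (the limit leaves the size open) in this estimate. For compound 4 the estimated value is 100000 nM with an expected range of 40000 nM to 200000 nM for the measurement.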

Compound 4, half-maximal inhibitory concentration: > 100000 nM
Compound 4 ended at the assay's limit; the forecaster's own chance of this, stated with the estimate: 85%; the middle value sits exactly at the limit.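

In this assay compound 4 gives > 100000 nM as a limit and not a number. Compound 3 also carries only a limit, so oxolan-2-yl in place of oxan-2-yl gives no readable step between compound 3 and compound 4. The compounds shown leave open whether any of them has a measurable value in this read-out: the limit of > 100000 nM in this assay, at which 4 of the 4 values shown sit.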